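Diaryl sulfone amides: the hydroxyphenyl-to-chlorophenyl step

The compounds below may be only part of what the source reports. "The series", "measured", "known", "first", "only" and "open" are said of these compounds alone.

Compounds with numbers so far:
compound 1 `CC(O)(C(=O)Nc1ccc(C#N)c(Sc2ccccc2)c1)C(F)(F)F`: 8300 nM
compound 2 `CC(O)(C(=O)Nc1ccc(S(=O)(=O)c2ccccc2O)cc1)C(F)(F)F`: 3090 nM
compound 3 `COc1cc(NC(=O)C(C)(O)C(F)(F)F)ccc1S(=O)(=O)c1ccccc1`: 5900 nM

All three share the amide-linked core and were run in a functional assay (Cavia porcellus) with sulfonylurea receptors; K-ATP channels (Homo sapiens) as the target; a lower number here means a stronger inhibitor, a higher number a weaker inhibitor. Compound 1 gives 8300 nM there, compound 3 gives 5900 nM, and compound 2 gives 3090 nM. Compound 2 holds the lowest number of the three; its gap to compound 3 lies within the scatter, so no order between those two can be read, while its gap to compound 1 lies beyond the scatter.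

Compound 4 `CC(O)(C(=O)Nc1ccc(S(=O)(=O)c2cccc(Cl)c2)cc1)C(F)(F)F` has not yet been measured. It differs from compound 2 by 3-chlorophenyl in place of 2-hydroxyphenyl on a sulfonyl sulfur. No pair among the measured compounds isolates this exchange, so the size of the step cannot be taken from a shown step. Given that compound 2 and compound 3, which differ on the sulfonyl-bound ring and on the core, still sit within the scatter of each other, the exchange is expected to move the number only modestly, if at all, with a slight lean toward a higher number. The estimated step of a 1.3-fold higher number from compound 2 to compound 4 (0.11 log units; within the scatter) is therefore small. For compound 4 the expected value in this assay is 4000 nM, with a range from 1500 nM to 11000 nM.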

Compound 4, half-maximal inhibitory concentration: 10000 nM
Beside the measured number, compound 4's estimate is 2.5-fold (0.40 log units) below it; measured number inside the range.
By their numbers in this assay, from the lowest: compounds 2, 3, 1 and 4 (each within the scatter of the next, the first and the last beyond it).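

In this assay, within the data shown here, the ring on the sulfonyl sulfur is not a silent position: 3-chlorophenyl in place of 2-hydroxyphenyl gives a 3.2-fold higher number from compound 2 to compound 4 (0.51 log units; beyond the scatter) and is the first exchange read in one place only. The two groups match in heavy-atom count and in their six-membered aromatic ring of carbon only, and they differ in chlorine for oxygen, in hydrogen-bond donor and acceptor counts, and in the number in the group's name. No evidence at hand bears on the cause of this step.

Going by these compounds, whether the step follows the atom on the ring or its place stays open, and 3-hydroxyphenyl or 2-chlorophenyl on the sulfonyl sulfur would separate the two. On these data alone, how an amine or a carboxylic acid on that ring would compare also stays open.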